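The source may hold more compounds than are shown below. What is called first, only, known or untested is meant among the compounds shown, and "the series" means these compounds.

Compound 1 `Cc1cccc(CN2CC=C(CCC(=O)NO)C2=O)c1` is one of three close relatives tested in a functional assay on MDA-MB-231 cells (Homo sapiens) for inhibition, read by sulforhodamine B assay (a lower number here means a stronger inhibitor of growth, a higher number a weaker inhibitor of growth), where compound 1 gives 1990 nM. Compound 2 `O=C(CCC1=CCN(Cc2ccc(F)cc2)C1=O)NO` gives 1940 nM in this assay, and compound 3 `O=C(CCC1=CCN(Cc2ccc(Cl)cc2)C1=O)NO` gives 1990 nM. The three numbers sit together: compound 1 is level with compound 3 at the digits shown, and all lie within the usual scatter of one another. Among the compounds with values here, the only single-point step among them, a 1.0-fold higher number from compound 2 to compound 3 (0.01 log units; within the scatter), stays within the scatter.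

Compound 4 `N#Cc1cccc(CN2CC=C(CCC(=O)NO)C2=O)c1` is the next step from compound 1, with the change (cyano in place of methyl on an aromatic carbon). Within the data shown here, no measured step swaps a methyl for a cyano, so the expectation rests on how little the one measured step, a 1.0-fold higher number from compound 2 to compound 3 (0.01 log units; within the scatter), moved. A step of no real size in this assay is therefore expected. Compound 4 is estimated at 2000 nM, with a range from 1000 nM to 4000 nM, which amounts to an expected 1.0-fold higher number from compound 1 to compound 4 (0.00 log units; within the scatter).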

Compound 4, concentration for 50% growth inhibition: 3600 nM
Compound 4: the middle estimate sits 1.8-fold (0.26 log units) below what was measured; low and high end bracket the measured number.
By their numbers in this assay, from the lowest: compounds 2, 1, 3 and 4 (each within the scatter of the next).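

Replacing methyl with cyano on this aromatic carbon, meta to a large group, adds a hydrogen-bond acceptor and a triple bond, yet this assay shows a 1.8-fold higher number from compound 1 to compound 4 (0.26 log units; within the scatter). Within the data shown here, the one earlier step only exchanged one halogen for another, so this is the first sign that a quite different group can sit at this position without a step beyond the scatter. No measurement here bears on the reason for this result. As far as these compounds go, whether an amine, a carboxylic acid or a longer chain on this carbon would shift growth inhibition beyond the scatter remains open.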